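Chloro for methyl on the pyridine of compound 1

The source may hold more compounds than are shown below. What is called first, only, known or untested is meant among the compounds shown, and "the series" means these compounds.

Values in a functional assay on K562 cells (Homo sapiens) for cytotoxicity, with a stated time of 72 h (on this read-out higher numbers stand for weaker inhibition and lower numbers for stronger inhibition), follow.

- compound 1 `Cc1cc(-c2c(-c3cccc(C)n3)nn3c2C(C)C(C)(C)C3)ccn1` reads > 100000 nM
- compound 2 `Cc1cccc(-c2nn3c(c2-c2ccncc2)C(C)C(C)(C)C3)c1C#N` reads 92000 nM
- compound 3 `COCC1c2c(-c3ccncc3)c(-c3cccc(C)n3)nn2CC1(C)C` reads > 100000 nM

Compound 1 reads > 100000 nM and that is a limit, not a number. Compound 3 reads > 100000 nM and that is also a limit. Among the compounds with values here, compound 2 gives the only number in the set, 92000 nM in this assay and no more. The picture is therefore framed by the limit of > 100000 nM in this assay, at which 2 of the 3 values shown sit, and compound 1 has no exact place on the scale.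

Compound 4 `Cc1cccc(-c2nn3c(c2-c2ccnc(Cl)c2)C(C)C(C)(C)C3)n1` has not yet been measured. Its difference from compound 1 is chloro in place of methyl on an aromatic carbon and it turns 2-methylpyridin-4-yl into 2-chloropyridin-4-yl, with chloro in place of methyl on an aromatic carbon.

Within the data shown here, no measured pair differs in one place only, so no step size can be read directly from the data. Among the measured compounds shown here, the expectation rests on compound 2 at 92000 nM as the only number available. No clear direction follows from that, and no step beyond the scatter is expected. The estimated change is a number no higher from compound 1 to compound 4 (the limit leaves the size open) and a further limit would not be a surprise. Compound 4 is expected at 100000 nM in this assay on this estimate. The estimated range for compound 4 runs from 50000 nM to 200000 nM in this assay as an expectation only.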

Compound 4, half-maximal inhibitory concentration: > 100000 nM
Compound 4: only a limit was reported; the forecaster's own chance of this, stated with the estimate: 60%; the middle value lies on the limit itself.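

No new step can be read between compound 1 and compound 4, as each is reported only as a limit in this assay: the limit of > 100000 nM in this assay, at which 3 of the 4 values shown sit.

The compounds shown leave open what exact values compound 1 and compound 4 would take, and so whether chloro in place of methyl on the pyridine changes the read-out at all.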